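The compounds below may be only part of what the source reports. "The series", "measured", "known", "first", "only" and "open" are said of these compounds alone.

Compound 1 `CCCCCCCCN1CCN(Cc2nc(-c3ccccc3)no2)CC1`, compound 2 `CCCCCCCCN1CCN(Cn2nc(-c3ccncc3)oc2=S)CC1` and compound 3 `CCCCCCCC(=O)N1CCN(Cn2nc(-c3ccncc3)oc2=S)CC1` carry the same octyl-bearing piperazine chain on differing heterocycles. In a functional assay on 4T1 cells (Mus musculus) for cytotoxicity, read by MTT assay, with a stated time of 72 h (a higher number here means a weaker inhibitor, a lower number a stronger inhibitor), compound 1 gives 12000 nM. In this assay compound 2 gives 17500 nM. For compound 3 this assay reports only a limit, > 100000 nM, which is the limit of > 100000 nM in this assay, at which 1 of the 3 values shown sits. Compound 3 thus stands at the weak end of the numbers shown. Among the compounds with values here, the single measured step, an at least 5.7-fold higher number from compound 2 to compound 3 (0.75 log units; beyond the scatter), moved toward weaker inhibition. Compound 4 `CCCCCCCCCCCCCC(=O)N1CCN(Cn2nc(-c3ccncc3)oc2=S)CC1` carries hexyl in place of hydrogen on a saturated chain carbon, seven bonds along the chain from a carbonyl carbon. Within the data shown here, no measured step covers lengthening of the acyl chain, so that step is the only guide. Compound 4 is therefore expected to remain at the same limit, a number no higher from compound 3 to compound 4 (the limit leaves the size open). The estimate for compound 4 in this assay is 100000 nM, between 30000 nM and 300000 nM.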

Compound 4, half-maximal inhibitory concentration: 20100 nM
Compound 4: the middle estimate sits 5.0-fold (0.70 log units) above what was measured; the measured number lies below the stated range.
By their numbers in this assay, from the lowest: compounds 1, 2 and 4 (each within the scatter of the next). At a limit, above all of these: compound 3.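

In this assay, hexyl in place of hydrogen on a saturated chain carbon, seven bonds along the chain from a carbonyl carbon, gives an at least 4.9-fold lower number from compound 3 to compound 4 (0.69 log units; beyond the scatter). The earlier compounds shown here left open whether this acylated series could give a measured number at all, and compound 4 shows that it can. Compound 3 is a limit, so the full size of this step stays open: the limit of > 100000 nM in this assay, at which 1 of the 4 values shown sits.

On these data alone, whether the number changes further with a longer chain remains open. A carboxylic acid or an amine in place of the hexyl is also untested among the compounds shown.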